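Capping the Ring Nitrogen of Compound 1 with Acetyl

The compounds below may be only part of what the source reports. "The series", "measured", "known", "first", "only" and "open" are said of these compounds alone.

Compound 1 `Cc1[nH]nc(N)c1-c1ccc(Cl)c(Cl)c1` gives > 100000 nM in an assay on Sf9 cells for inhibition of mitogen-activated protein kinase kinase kinase 14 (Homo sapiens), read by ADP-Glo, with a stated time of 60 min; on this read-out higher numbers stand for weaker inhibition and lower numbers for stronger inhibition; this value is a limit of the assay, not a number.
Compound 2 `Cc1[nH]nc(N)c1-c1cccc(Cl)c1` gives > 100000 nM in this assay; this value is likewise a limit, not a number.
Compound 3 `CC(=O)n1nc(C)c(Br)c1N` gives > 100000 nM in this assay; this value too is a limit, not a number.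

All three measured compounds sit at the limit of > 100000 nM in this assay, at which 3 of the 3 values shown sit, so compound 1 has no measured position beyond that limit. The single one-change step shown, a step that the two limits leave unreadable from compound 1 to compound 2, has no readable size, as both ends are limits.

Compound 4 `CC(=O)n1nc(N)c(-c2ccc(Cl)c(Cl)c2)c1C` differs from compound 1 by acetyl in place of hydrogen on an aromatic nitrogen. Among the compounds with values here, no measured step bears directly on this change. Compound 3, which also carries an acetyl on a ring nitrogen, sits at the same limit, and the step from compound 1 to compound 2 gives no size at all. Nothing in these data therefore points to a gain in potency, and the expected outcome for compound 4 is another limit, with an expected step of a number no higher from compound 1 to compound 4 (the limit leaves the size open). The estimate for compound 4 is 100000 nM, between 30000 nM and 300000 nM.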

Compound 4, half-maximal inhibitory concentration: > 100000 nM
Compound 4 ended at the assay's limit; the forecaster's own chance of this, stated with the estimate: 85%; the middle value sits exactly at the limit.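

Compound 1 and compound 4 both stand at a limit of the assay, not at a number, so the step between them cannot be read: the limit of > 100000 nM in this assay, at which 4 of the 4 values shown sit.

The compounds shown leave open whether acetyl on the ring nitrogen changes inhibition at all, and how these compounds rank against one another in this assay.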